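The source may hold more compounds than are shown below. What is called first, only, known or untested is meant among the compounds shown, and "the series" means these compounds.

Measured so far in an ADME assay on L02 cells (Homo sapiens) for cytotoxicity, read by MTT assay; a higher number here means a weaker inhibitor, a lower number a stronger inhibitor:
- Compound 1 `COc1ccc(/C=C/C(=O)c2ccc(OC)c3c2OC(C)(C)C=C3)cc1OCCO`: > 10000 nM, a limit of the assay and not a number
- Compound 2 `COc1ccc(/C=C/C(=O)c2ccc(OC)c3c2OC(C)(C)C=C3)cc1OC(=O)c1ccc(Br)cc1`: 8400 nM

Among the compounds with values here, compound 2 holds the only actual number so far, 8400 nM. Compound 3 `COc1ccc(/C=C/C(=O)c2ccc(OC)c3c2OC(C)(C)C=C3)cc1CS(C)(=O)=O` differs from it as follows: (methylsulfonyl)methyl in place of ((4-bromophenyl)carbonyl)oxy on an aromatic carbon. In short, (methylsulfonyl)methyl stands in place of ((4-bromophenyl)carbonyl)oxy on an aromatic carbon. Within the data shown here, the one measured step that bears on this is an at least 1.1-fold lower number from compound 1 to compound 2 (0.07 log units; that floor lies within the scatter). Compound 1 also lacks the (4-bromophenyl)carbonyl group, and its > 10000 nM is a limit. A small move towards a higher number in this assay is therefore expected, a 1.2-fold higher number from compound 2 to compound 3 (0.08 log units; within the scatter), perhaps nothing beyond the scatter. For compound 3 the estimated value is 10000 nM, with an expected range of 4500 nM to 25000 nM.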

Compound 3, half-maximal inhibitory concentration: > 10000 nM
Compound 3: no number, only a limit; the forecaster's own chance of this, stated with the estimate: 50%; the middle value sits exactly at the limit.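

In this assay, (methylsulfonyl)methyl in place of ((4-bromophenyl)carbonyl)oxy on this aromatic carbon gives an at least 1.1-fold higher number from compound 2 to compound 3 (0.07 log units; that floor lies within the scatter), so no real change can be claimed. The step from compound 1 to compound 3 cannot be read, as both values are limits. Compound 3, like compound 1, gives no actual number, so this assay cannot separate their groups: the limit of > 10000 nM in this assay, at which 2 of the 3 values shown sit.

As far as these compounds go, how far compound 1 and compound 3 lie past that limit stays unknown. From the compounds shown here alone, whether an amine or a carboxylic acid on this aromatic carbon would give a clearly lower number than compound 2 also stays open.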